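This account rests on a few compounds, and the source may have more. Where it says the series, first, only, none or still open, it means among the compounds named here.

Measured in an ADME assay on Vero 76 cells (Chlorocebus sabaeus) for cytotoxicity, read by MTT assay, with a stated time of 96 h; on this read-out lower numbers stand for higher toxicity in this test and higher numbers for lower toxicity in this test:
- compound 1 `Cc1ccc(C2CC(c3ccccc3)=NN2c2ccc(S(N)(=O)=O)cc2)cc1`: 20000 nM
- compound 2 `NS(=O)(=O)c1ccc(N2N=C(c3ccccc3)CC2c2ccccc2Cl)cc1`: 26000 nM

Compound 2 stands level with compound 1 within the scatter, so neither can be ranked over the other in this assay. The next compound to be tested, compound 3 `Cc1cccc(C2CC(c3ccccc3)=NN2c2ccc(S(N)(=O)=O)cc2)c1`, has 3-methylphenyl in place of 2-chlorophenyl on a saturated ring carbon.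

Within the data shown here, only one measured step bears on this change. It is a 1.3-fold higher number from compound 1 to compound 2 (0.11 log units; within the scatter), which exchanged 2-chlorophenyl and 4-methylphenyl on that same saturated ring carbon and stayed within the scatter. Among the measured compounds shown here, compound 3 keeps a methylphenyl group, as compound 1 does with 20000 nM, but no compound with 3-methylphenyl has been measured yet. With two values as the whole basis, this guide is thin, and no step beyond the scatter is expected in this assay.

The estimate is a 1.2-fold lower number from compound 2 to compound 3 (0.07 log units; within the scatter), an expected change that stays within the scatter. For compound 3 the expected value is 22000 nM, with an estimated range of 11000 nM to 45000 nM.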

Compound 3, half-maximal cytotoxic concentration: 25000 nM
Beside the measured number, compound 3's estimate is 1.1-fold (0.06 log units) below it; measured number inside the range.
By their numbers in this assay, from the lowest: compounds 1, 3 and 2 (each within the scatter of the next).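

In this assay, the exchange of 2-chlorophenyl for 3-methylphenyl on the saturated ring carbon gives a 1.0-fold lower number from compound 2 to compound 3 (0.02 log units; within the scatter), so this second exchange at the position also stays within the scatter and a chlorine-bearing and a methyl-bearing phenyl group cannot be told apart here. Among these compounds, the new compound also allows the first comparison of two methylphenyl groups at this position, and the change from 4-methylphenyl to 3-methylphenyl gives a 1.3-fold higher number from compound 1 to compound 3 (0.10 log units; within the scatter), again with no readable difference, so all three substituted phenyl groups now stand level in this read-out. No supporting data are available to explain why these values stay level.

The compounds shown leave open whether a more different group on this phenyl ring, such as an amine or a carboxylic acid, or a longer chain in place of the methyl, would move the value beyond the scatter. They also leave open whether a change at the ring atom that bears a phenyl group would do so, since that group is the same in all three compounds.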